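A few compounds are considered here, and "the series" means these few. Any claim that something is new, unique, unknown or untested is made for them only; others in the source may bear on it.

Three compounds share a common core in which two aryl units are joined through a four-carbon chain with an oxygen at each end. Compound 1 `COc1cc(C(=O)O)ccc1OCCCCOc1ccc(C(=O)CC(C)C)c(O)c1C` gives 40 nM in an assay on HEK293 cells for positive allosteric modulation of metabotropic glutamate receptor 2 (Rattus norvegicus), read by thallium flux, with a stated time of 2.5 min; on this read-out higher numbers stand for an effect only at larger amounts of compound and lower numbers for an effect already at smaller amounts. Compound 2 `CC(=O)c1ccc(OCCCCOc2ccc(C(=O)O)cc2C)c(C)c1O` gives 50 nM in this assay. Compound 3 `COc1cc(C(=O)O)ccc1OCCCCOc1ccc(C(=O)CC(C)(C)C)c(O)c1C` gives 47 nM in this assay. On these numbers compound 3 stands second highest of the three, with compound 2 nearest and compound 1 furthest, and both gaps lie within the scatter, so no order among them can be read.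

For the measured compounds named here, the only single-place step measured is a 1.2-fold higher number from compound 1 to compound 3 (0.07 log units; within the scatter), where a methyl enters on a saturated chain carbon; it changed nothing beyond the scatter.

Compound 4 `COc1cc(C(=O)O)ccc1OCCCCOc1ccc(C(C)=O)c(O)c1C` differs from compound 3 by hydrogen in place of tert-butyl on a saturated chain carbon bound to a carbonyl carbon, which reads, cut one bond further out, as neopentyl to methyl, or neopentylcarbonyl to acetyl. The measured step from compound 1 to compound 3 shows that adding branching on this chain left the number unchanged, and compound 2, which already carries an acetyl group though it differs elsewhere, sits alongside the other two. Removing the tert-butyl is therefore expected to give no step beyond the scatter, an expected 1.1-fold higher number from compound 3 to compound 4 (0.03 log units; within the scatter). Compound 4 is estimated at 50 nM, in a range from 20 nM to 125 nM.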

Compound 4, half-maximal effective concentration: 161 nM
Beside the measured number, compound 4's estimate is 3.2-fold (0.51 log units) below it; measured number outside the range, above it.
By their numbers in this assay, from the lowest: compounds 1, 3 and 2 (each within the scatter of the next); then compound 4.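

In this assay, the group on the saturated chain carbon bound to a carbonyl carbon turns out to matter: there is a 3.4-fold higher number from compound 3 to compound 4 (0.53 log units; beyond the scatter) and a 4.0-fold higher number from compound 1 to compound 4 (0.60 log units; beyond the scatter) when tert-butyl or isopropyl gives way to hydrogen, leaving an acetyl group, and both steps lie beyond the scatter. The earlier step between the two branched compounds showed only that isopropyl and tert-butyl could not be told apart here, whereas this change shows that removing the branched group altogether can be felt. The acetyl group alone does not settle the number either, since compound 2 also carries one and there is a 3.2-fold higher number from compound 2 to compound 4 (0.51 log units; beyond the scatter) with methoxy in place of methyl on an aromatic carbon, again beyond the scatter.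

The compounds shown leave open how much of the group is needed, as a straight ethyl or propyl chain in this place could fall on either side of the gap, and an amine there would test something else again. Nothing measured alongside these numbers gives a cause for these steps.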